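1H-pyrrol-2-yl for 1,3-benzoxazol-2-yl: a step among limits

The compounds below may be only part of what the source reports. "The series", "measured", "known", "first", "only" and "open" are said of these compounds alone.

In a toxicity assay on NIH3T3 cells (Mus musculus) for cytotoxicity, read by resazurin assay (a higher number here means that more compound is needed for the effect, a lower number that less compound is needed), compound 1 `Clc1ccc(NCc2cncn2Cc2ccc(-c3ccccc3)cc2)cc1-c1ccccc1` gives > 1000 nM as a limit, not a number. Compound 2 `c1ccc(-c2ccc(Cn3cncc3CNc3ccc(-c4ccccc4)c(-c4ccccc4)c3)cc2)cc1` gives > 10000 nM as a limit too. Compound 3 `c1ccc(-c2ccc(Cn3cncc3CNc3ccc(-c4nc5ccccc5o4)c(-c4ccccc4)c3)cc2)cc1` gives > 10000 nM as a limit as well, so no number places it within the series.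

Compound 4 `c1ccc(-c2ccc(Cn3cncc3CNc3ccc(-c4ccc[nH]4)c(-c4ccccc4)c3)cc2)cc1` carries 1H-pyrrol-2-yl in place of 1,3-benzoxazol-2-yl on an aromatic carbon, ortho to a phenyl group (1H-pyrrol-2-yl in place of 1,3-benzoxazol-2-yl on an aromatic carbon). For the measured compounds named here, three measured steps bear on this change, all at that carbon: (a step that the two limits leave unreadable from compound 2 to compound 3), (a step that the two limits leave unreadable from compound 1 to compound 2) and (a step that the two limits leave unreadable from compound 1 to compound 3). None has a readable size.

No step beyond the scatter is expected in this assay, and the estimated step is (a number no higher from compound 3 to compound 4 (the limit leaves the size open)). For compound 4 the estimated value is 10000 nM (range 4000 nM to 20000 nM), and a report as a limit is expected.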

Compound 4, half-maximal effective concentration: > 10000 nM
Compound 4 gave a limit, no number; the forecaster's own chance of this, stated with the estimate: 85%; the middle value sits exactly at the limit.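

In this assay compound 4 gives > 10000 nM, a limit and not a number. Its steps from compound 1, compound 2 and compound 3 cannot be read. The compounds shown leave open where any of the four reaches its half-maximal effect.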